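Growing the methylcarbamoyl group of compound 2 to isobutylcarbamoyl

The compounds below may be only part of what the source reports. "The series", "measured", "known", "first", "only" and "open" are said of these compounds alone.

In a functional assay on MCF7 cells (Homo sapiens) for antiproliferative activity, read by CCK-8 assay, with a stated time of 72 h (a lower number here means a stronger inhibitor of growth, a higher number a weaker inhibitor of growth), compound 2 `CC[C@@H]1C(=O)N(C)c2cnc(-n3ccc4cc(C(=O)NC)ccc43)nc2N1C1CCCC1` gives 1000 nM as the lowest number of the three measured. Compound 1 `CCCNS(=O)(=O)c1ccc(Nc2ncc3c(n2)N(c2ccn(C)n2)C(CC)C(=O)N3C)cc1` stands at 3000 nM and compound 3 `CCC1C(=O)N(C)c2cnc(Nc3ccc(S(N)(=O)=O)cc3)nc2N1c1ccn(C)n1` at 36600 nM on the same read-out. Compound 4 `CC[C@@H]1C(=O)N(C)c2cnc(-n3ccc4cc(C(=O)NCC(C)C)ccc43)nc2N1C1CCCC1` carries isobutylcarbamoyl where compound 2 has methylcarbamoyl. The change isopropyl in place of hydrogen on a saturated chain carbon bound to an amide-type nitrogen puts isopropyl in place of hydrogen on a saturated chain carbon bound to an amide-type nitrogen. Among the compounds with values here, only one measured step bears on this, and only loosely: hydrogen in place of propyl on a sulfonamide nitrogen gave a 12-fold higher number from compound 1 to compound 3 (1.09 log units; beyond the scatter) on a different core. Read in reverse, that step hints that a longer chain can lower the number, but no change to the amide chain of compound 2 has been measured. A much smaller shift in the same direction is therefore expected, and the expected step is a 1.7-fold lower number from compound 2 to compound 4 (0.22 log units; within the scatter) in this comparison. Compound 4 is estimated at 600 nM with an expected range from 150 nM to 2500 nM in this assay overall.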

Compound 4, concentration for 50% growth inhibition: 953 nM
The estimate for compound 4 lay 1.6-fold (0.20 log units) below the measured number; low and high end bracket the measured number.
By their numbers in this assay, from the lowest: compounds 4 and 2 (each within the scatter of the next); then compound 1; then compound 3.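

In this assay, compound 4 and compound 2 cannot be told apart (a 1.0-fold lower number from compound 2 to compound 4 (0.02 log units; within the scatter)), so growing methylcarbamoyl to isobutylcarbamoyl leaves the read-out where it stood. Within the data shown here, this is the first measured change at this position, and it shows that isopropyl in place of hydrogen on a saturated chain carbon bound to an amide-type nitrogen is accommodated without a step beyond the scatter, in contrast to the large step at the sulfonamide nitrogen on the other core (a 12-fold higher number from compound 1 to compound 3 (1.09 log units; beyond the scatter)). Nothing on hand explains this flat result. As far as these compounds go, whether a terminal amine, a carboxylic acid or a much longer chain at this position would shift the number remains open. So does the effect of replacing the amide hydrogen with a methyl group.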